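The compounds below may be only part of what the source reports. "The series", "measured", "known", "first", "only" and "open" are said of these compounds alone.

Working notes on the series.

Compound 2 `Cc1cc(C)c(CN2CCc3c(Cl)cc([C@@H](CO)[C@@H]4CCCO4)c(Cl)c3C2=O)c(=O)[nH]1` gives 1570 nM in an assay on cells for inhibition of histone-lysine N-methyltransferase EZH2 (Homo sapiens), read by ELISA, with a stated time of 72 h (a higher number here means a weaker inhibitor, a lower number a stronger inhibitor), the lowest of the two numbers recorded there. Compound 1 `Cc1cc(C)c(CN2CCc3c(Cl)cc([C@@H](CO)[C@@H]4CCOC4)c(Cl)c3C2=O)c(=O)[nH]1` gives 2910 nM in this assay, and the step of a 1.9-fold lower number from compound 1 to compound 2 (0.27 log units; within the scatter) lies within the scatter, so the two compounds cannot be ordered.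

Compound 3 `Cc1cc(C)c(CN2CCc3c(Cl)cc([C@@H](C)CO)c(Cl)c3C2=O)c(=O)[nH]1` differs from compound 2 by a group of 4 heavy atoms (3 carbon, 1 oxygen; no ring) in place of a group of 8 heavy atoms (6 carbon, 2 oxygen; one five-membered non-aromatic ring with 1 hetero atom), on an aromatic carbon. Going by the values given here, the only measured step, from compound 1 to compound 2, exchanges one oxolanyl ring for another and says nothing about removing the ring altogether; no measured step bears directly on the change to compound 3. Among the compounds with values here, since the single measured step stayed within the scatter, the expectation for compound 3 is a step of a 1.6-fold higher number from compound 2 to compound 3 (0.20 log units; within the scatter) in this assay with no confident direction and a wide range. Compound 3 is estimated at 2500 nM in this assay, between 700 nM and 9000 nM.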

Compound 3, half-maximal inhibitory concentration in the histone-lysine N-methyltransferase EZH2 assay: 1040 nM
Beside the measured number, compound 3's estimate is 2.4-fold (0.38 log units) above it; measured number inside the range.
By their numbers in the histone-lysine N-methyltransferase EZH2 assay, from the lowest: compounds 3, 2 and 1 (each within the scatter of the next, the first and the last beyond it).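

In the histone-lysine N-methyltransferase EZH2 assay, this position on an aromatic carbon accepts 1-(hydroxymethyl)ethyl, with no ring, in place of the oxolanyl-bearing group without any loss: the change gives a 1.5-fold lower number from compound 2 to compound 3 (0.18 log units; within the scatter) and a 2.8-fold lower number from compound 1 to compound 3 (0.45 log units; beyond the scatter). Only the second of these steps lies beyond the scatter, and it is modest, so the ring is not required for the number reached in this assay. The same change does separate the pair in a physicochemical assay for solubility, measured as kinetic solubility (a higher number here means a more soluble compound, a lower number a less soluble compound), where compound 2 gives 550000 nM and stands higher than compound 3, which gives 143000 nM: the measured solubility of compound 2, 550000 nM, and of compound 3, 143000 nM, a 3.8-fold lower number (0.59 log units; beyond the scatter)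

From the compounds shown here alone, all three compounds keep the hydroxyl on the chain, so what an amine or a carboxylic acid in its place would do in the histone-lysine N-methyltransferase EZH2 assay stays open. Going by these compounds, the outcome in either assay for a longer chain at this position also stays open.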